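The compounds below may be only part of what the source reports. "The series", "measured", "known", "first", "only" and "open" are said of these compounds alone.

In a functional assay on CCRF-CEM cells (Homo sapiens) for antiproliferative activity, read by sulforhodamine B assay, with a stated time of 48 h (a lower number here means a stronger inhibitor, a higher number a weaker inhibitor), the series stands as follows:

- Compound 1 `O=C1NCCN1c1ccc(S(=O)(=O)Nc2ccc3[nH]ccc3c2)cc1` gives 410 nM
- Compound 2 `CCc1cccc(NS(=O)(=O)c2ccc(N3CCNC3=O)cc2)c1` gives 200 nM
- Compound 3 `COc1cc(NS(=O)(=O)c2ccc(N3CCNC3=O)cc2)cc(OC)c1OC` gives 23 nM

Compound 2 holds the middle place of the three. Its number is lower than that of compound 1 (410 nM) by a gap only just beyond the scatter, and higher than that of compound 3 (23 nM) by a gap well beyond it.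

The next compound to be read is compound 4 `Cc1cc(C)cc(NS(=O)(=O)c2ccc(N3CCNC3=O)cc2)c1`. The change from compound 2 is 3,5-dimethylphenyl in place of 3-ethylphenyl on a sulfonamide nitrogen and amounts to 3,5-dimethylphenyl in place of 3-ethylphenyl on a sulfonamide nitrogen. The two compounds have the same atoms, joined differently.

Among the measured compounds shown here, no two measured compounds differ in one place only, so the series gives no direct size for a change of this kind. Since the entering and leaving groups match in every count, no step beyond the scatter is expected in this assay. The estimated step is a 1.3-fold lower number from compound 2 to compound 4 (0.10 log units; within the scatter) and would stay within the scatter. The range is kept wide, as the three measured compounds carry different groups on the sulfonamide nitrogen and their values lie far apart, with compound 3 at 23 nM as the low end.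

Compound 4 is estimated at 160 nM (expected range 60 nM to 450 nM).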

Compound 4, half-maximal inhibitory concentration: 170 nM
Estimate against measurement, compound 4: 1.1-fold (0.03 log units) below, within the range that was stated.
By their numbers in this assay, from the lowest: compound 3; then compounds 4 and 2 (each within the scatter of the next); then compound 1.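

In this assay, the step from 3-ethylphenyl to 3,5-dimethylphenyl on the sulfonamide nitrogen is a 1.2-fold lower number from compound 2 to compound 4 (0.07 log units; within the scatter) and gives the series its first reading of a change in one place. At this position, the two groups, which have the same atoms joined differently, are not told apart by this assay, but this single pair says nothing about other groups on this nitrogen. No measurement on these compounds bears on the result, and the two values alone cannot say why the two groups read alike. 

From the compounds shown here alone, it remains open whether this tolerance extends to groups of another kind on the phenyl ring, such as an amine, a carboxylic acid or a longer chain like butyl, and whether any of them would move the number beyond the scatter from that of compound 2. The part of the molecule on the other side of the sulfonyl group is the same in all the compounds shown, so the effect of a change there on the number also remains open.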